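Methyl in Place of Bromo on a Second Core

A few compounds are considered here, and "the series" means these few. Any claim that something is new, unique, unknown or untested is made for them only; others in the source may bear on it.

Compound 1 `O=C1/C(=C/c2cccc(Br)c2)Cc2ccccc21` gives 21000 nM in a functional assay on P388 cells (Mus musculus) for inhibition; a lower number here means a stronger inhibitor, a higher number a weaker inhibitor.
Compound 2 `Cc1cccc(/C=C2\Cc3ccccc3C2=O)c1` gives 24900 nM in this assay.
Compound 3 `O=C1/C(=C/c2ccc(Br)cc2)CCc2ccccc21` gives 20400 nM in this assay.

The three measured values sit close together. Compound 3 has the lowest number, but its gaps to compound 1 and to compound 2 are both within the usual scatter, so none of the three can be called the stronger or weaker inhibitor.

Compound 1 and compound 2 differ in one place: methyl in place of bromo on an aromatic carbon. That change gave a 1.2-fold higher number from compound 1 to compound 2 (0.07 log units; within the scatter), a step that stays within the scatter.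

Compound 4 `Cc1ccc(/C=C2\CCc3ccccc3C2=O)cc1` is not yet measured. It differs from compound 3 in one place: methyl in place of bromo on an aromatic carbon. The difference between the core of compound 3 and the core of compound 1 is not broken down here. Around the place of the change there is a difference in words as well: in the first pair the new group sits meta to a large group, in the second pair para to a large group. The two changes are therefore the same kind of change, not the same change.

On this footing a small step is expected, a 1.2-fold higher number from compound 3 to compound 4 (0.07 log units; within the scatter), in line with the earlier one, because a 1.2-fold higher number from compound 1 to compound 2 (0.07 log units; within the scatter) stayed within the scatter. Compound 4 is estimated at 24000 nM in this assay, expected to fall between 12000 nM and 50000 nM.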

Compound 4, half-maximal inhibitory concentration: 17700 nM
Estimate against measurement, compound 4: 1.4-fold (0.13 log units) above; low and high end bracket the measured number.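

On the second core, in this assay, methyl in place of bromo on an aromatic carbon gave a 1.2-fold lower number from compound 3 to compound 4 (0.06 log units; within the scatter). Set beside the earlier step, this shows that the change carried over in the one sense these data allow, with both steps staying small and no measurable difference between them: the same change on two cores in this assay, a 1.2-fold higher number (0.07 log units; within the scatter) from compound 1 to compound 2 and a 1.2-fold lower number (0.06 log units; within the scatter) from compound 3 to compound 4, 1.4-fold (0.14 log units) apart, within the scatter of two such steps. Within the data shown here, it does not show that the exchange is neutral in general: only two pairs are at hand, they differ in both the core and the place of the change, and neither influence can be separated from the other, while the opposite signs of two steps this small carry no meaning.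

The compounds shown leave open whether a different group at this place, such as an amine, a carboxylic acid or a longer chain, would move the number beyond the scatter on either core. They also leave open whether methyl in place of bromo would stay as small on a further core, or at the other place on each of these two cores, so the agreement seen here rests on these two pairs alone.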